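The source may hold more compounds than are shown below. What is called first, only, known or untested is meant among the compounds shown, and "the series" means these compounds.

Measured compounds:
compound 1 `Cc1cc(=O)n(-c2ccccc2Cl)nc1C(=O)Nc1ccc(Oc2ncnc3c2ccn3C)cc1`: 11200 nM
compound 2 `Cc1cc(=O)n(-c2ccccc2C(F)(F)F)nc1C(=O)Nc1ccc(Oc2ncnc3c2ccn3C)c(F)c1`: > 60000 nM

In a functional assay on HepG2 cells (Homo sapiens) for cytotoxicity, read by MTT assay, with a stated time of 72 h (on this read-out higher numbers stand for weaker inhibition and lower numbers for stronger inhibition), compound 1 gives 11200 nM. For compound 2 this assay records only a limit, > 60000 nM, so compound 2 stands at the edge of the measured range (the limit of > 60000 nM in this assay, at which 1 of the 2 values shown sits). Compound 3 `Cc1cc(=O)n(-c2ccccc2Cl)nc1C(=O)Nc1ccc(Oc2ncnc3c2ccn3C)c(F)c1` differs from compound 2 by chloro in place of trifluoromethyl on an aromatic carbon. Compound 1 carries the same chloro group and returns a number rather than a limit. Within the data shown here, no measured step covers this change; the step from compound 2 to compound 3 is expected to be an at least 2.7-fold lower number from compound 2 to compound 3 (0.43 log units; beyond the scatter), toward stronger inhibition. Compound 3 is expected to give 22000 nM, within 7000 nM to 60000 nM.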

Compound 3, half-maximal inhibitory concentration: > 60000 nM
Compound 3: no number, only a limit; the forecaster's own chance of this, stated with the estimate: 30%; middle value at least 2.7-fold (0.43 log units) from the limit.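

In this assay, fluoro in place of hydrogen on an aromatic carbon gives an at least 5.3-fold higher number from compound 1 to compound 3 (0.72 log units; beyond the scatter), so with chloro held constant this position moves the read-out toward weaker inhibition. Compound 3 returns only a limit, and the step between compound 2 and compound 3 cannot be read, leaving chloro and trifluoromethyl unseparated when fluoro is present. The fluoro compounds now rest on the assay limit: the limit of > 60000 nM in this assay, at which 2 of the 3 values shown sit.

Open: whether a methoxy or an amine in place of fluoro shifts the read-out likewise, and whether trifluoromethyl differs from chloro without fluoro.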